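The compounds below may be only part of what the source reports. "The series", "measured", "known", "first", "only" and "open" are said of these compounds alone.

Compound 1 `CC[C@H](C)[C@H](N)CN(C(=O)[C@@H]1C[C@H]1c1cccc(C#N)c1)c1ccc(-c2ccccc2)cc1`; in a functional assay for agonist activity at G protein-coupled receptor 88 (Homo sapiens), read by HTRF and cAMP accumulation (on this read-out lower numbers stand for an effect already at smaller amounts and higher numbers for an effect only at larger amounts of compound), compound 1 gives 1600 nM.
Compound 2 `CC[C@H](C)[C@H](N)CN(C(=O)[C@@H]1C[C@H]1c1nc(C)cs1)c1ccc(-c2ccccc2)cc1`; in this assay compound 2 gives 730 nM.

Compound 2 holds the lower of the two numbers, set apart from compound 1 by a 2.2-fold lower number from compound 1 to compound 2 (0.34 log units; beyond the scatter). Compound 3 `CC[C@H](C)[C@H](N)CN(C(=O)[C@@H]1C[C@H]1c1ncc(C)s1)c1ccc(-c2ccccc2)cc1` differs from compound 2 only in that (5-methyl-1,3-thiazol-2-yl in place of 4-methyl-1,3-thiazol-2-yl on a saturated ring carbon). Among the compounds with values here, no measured step moves a methyl around a thiazole; the single measured step, a 2.2-fold lower number from compound 1 to compound 2 (0.34 log units; beyond the scatter), exchanges the whole ring and bears on this change only loosely. The step of a 1.1-fold higher number from compound 2 to compound 3 (0.04 log units; within the scatter) is therefore expected to stay within the scatter. Compound 3 is estimated at 800 nM, in a range from 350 nM to 2000 nM.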

Compound 3, half-maximal effective concentration: 1300 nM
Compound 3: the middle estimate sits 1.6-fold (0.21 log units) below what was measured, within the range that was stated.
By their numbers in this assay, from the lowest: compounds 2, 3 and 1 (each within the scatter of the next, the first and the last beyond it).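

In this assay, the 5-methyl-1,3-thiazol-2-yl of compound 3 and the 4-methyl-1,3-thiazol-2-yl of compound 2 cannot be told apart (a 1.8-fold higher number from compound 2 to compound 3 (0.25 log units; within the scatter)), so the methyl's place on the thiazole shows no effect beyond the scatter here. The 5-methyl-1,3-thiazol-2-yl also stays within the scatter of 3-cyanophenyl (a 1.2-fold lower number from compound 1 to compound 3 (0.09 log units; within the scatter)), whereas the 4-methyl-1,3-thiazol-2-yl lay beyond it (a 2.2-fold lower number from compound 1 to compound 2 (0.34 log units; beyond the scatter)). No evidence on the cause is at hand. The compounds shown leave open how a thiazole without the methyl, or one carrying an ethyl instead, would read in this assay.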